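A few compounds are considered here, and "the series" means these few. Any claim that something is new, unique, unknown or untested is made for them only; others in the source may bear on it.

Measured compounds and their values in a functional assay on MKN-74 cells (Homo sapiens) for antiproliferative activity, with a stated time of 24 h; a higher number here means a weaker inhibitor, a lower number a stronger inhibitor:
Compound 1 `NC(=O)c1c(NC(=O)c2ccccc2Cl)sc2c1CCN(Cc1c(Cl)cccc1Cl)C2` gives 4740 nM.
Compound 2 `NC(=O)c1c(NC(=O)c2ccccc2Cl)sc2c1CCN(C(=S)Nc1ccccc1Br)C2` gives 10800 nM.
Compound 3 `NC(=O)c1c(NC(=O)c2ccccc2Cl)sc2c1CCN(C(=S)Nc1ccccc1C(F)(F)F)C2` gives 1870 nM.

Compound 3 has the lowest number of the three in this assay; compound 1 sits nearest and compound 2 furthest above it. Compound 4 `COc1ccccc1NC(=S)N1CCc2c(sc(NC(=O)c3ccccc3Cl)c2C(N)=O)C1` differs from compound 3 by methoxy in place of trifluoromethyl on an aromatic carbon. Going by the values given here, no measured step swaps a trifluoromethyl for a methoxy, so the only guide is the step of a 5.8-fold lower number from compound 2 to compound 3 (0.76 log units; beyond the scatter), which shows that the group at this position can move the number by a modest amount. Since methoxy is neither bromo nor trifluoromethyl, the direction is uncertain, but compound 4 is expected to lose some of what compound 3 gained, an expected step of a 2.7-fold higher number from compound 3 to compound 4 (0.43 log units; beyond the scatter). Compound 4 is therefore estimated at 5000 nM, within a range of 1500 nM to 16000 nM.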

Compound 4, half-maximal inhibitory concentration: 35200 nM
Compound 4: middle estimate off by 7.0-fold (0.85 log units), on the low side; measured number above the stated range.
By their numbers in this assay, from the lowest: compound 3; then compound 1; then compound 2; then compound 4.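

In this assay, the group on the aromatic carbon ortho to a large group proves able to move the number much further than the earlier bromo to trifluoromethyl swap suggested, with methoxy giving (a 19-fold higher number from compound 3 to compound 4 (1.27 log units; beyond the scatter)) and (a 3.3-fold higher number from compound 2 to compound 4 (0.51 log units; beyond the scatter)). At this place, the order from lowest number is now trifluoromethyl, bromo, methoxy. Compound 4 also stands apart from the compound with a different group on the ring amine nitrogen (a 7.4-fold higher number from compound 1 to compound 4 (0.87 log units; beyond the scatter)), and nothing available explains these differences.

As far as these compounds go, how a methyl, a chloro or an amine would rank at this place remains open. So does whether this order would hold with these groups elsewhere on that ring.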